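Swapping an Ester for a Pyridyl Amide on Two Cores

This account rests on a few compounds, and the source may have more. Where it says the series, first, only, none or still open, it means among the compounds named here.

Three compounds have been measured in an ADME assay on microsomes from liver (Homo sapiens) for metabolic stability, read by LC-MS, with a stated time of 60 min, tested at 1 uM; on this read-out lower numbers stand for slow clearance and higher numbers for fast clearance:
compound 1 `CCOC(=O)c1cc(-c2csc(Nc3ccc(C)cc3)n2)on1` gives 189 mL/min/kg;
compound 2 `Cc1ccc(Nc2nc(-c3cc(C(=O)Nc4ccccn4)no3)cs2)cc1` gives 38.8 mL/min/kg;
compound 3 `CCOC(=O)c1cc(-c2coc(Nc3ccc(C)cc3)n2)on1` gives 226 mL/min/kg.

The cores of compound 1 and compound 3 differ, and that difference is not broken down here; in this assay their two values lie within the scatter of each other. Compound 1 and compound 2 differ in one place, ((pyridin-2-yl)amino in place of ethoxy on a carbonyl carbon), and this gave a 4.9-fold lower number from compound 1 to compound 2 (0.69 log units; beyond the scatter).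

Compound 4 `Cc1ccc(Nc2nc(-c3cc(C(=O)Nc4ccccn4)no3)co2)cc1` has not yet been measured. It differs from compound 3 by (pyridin-2-yl)amino in place of ethoxy on a carbonyl carbon, the same change as from compound 1 to compound 2, at the same kind of place. The step is expected to read a 4.9-fold lower number from compound 3 to compound 4 (0.69 log units; beyond the scatter), resting on the step of a 4.9-fold lower number from compound 1 to compound 2 (0.69 log units; beyond the scatter) seen on the other core. Compound 4 is therefore estimated at 46 mL/min/kg in this assay, between 20 mL/min/kg and 110 mL/min/kg.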

Compound 4, clearance in the Homo sapiens assay: 41.5 mL/min/kg
Estimate against measurement, compound 4: 1.1-fold (0.04 log units) above; the measured number falls inside the stated range.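

In the Homo sapiens assay, putting (pyridin-2-yl)amino in place of ethoxy on the carbonyl carbon gave a 5.4-fold lower number from compound 3 to compound 4 (0.74 log units; beyond the scatter), and the step matches the one seen on the other core: the same change on two cores in the Homo sapiens assay, a 4.9-fold lower number (0.69 log units; beyond the scatter) from compound 1 to compound 2 and a 5.4-fold lower number (0.74 log units; beyond the scatter) from compound 3 to compound 4, 1.1-fold (0.05 log units) apart, within the scatter of two such steps. The change therefore carried over between these two cores at much the same size, but two cores cannot show that it would hold on any other core, nor why the number falls. In a physicochemical assay for solubility, read by LC-MS, measured as kinetic solubility, with a stated time of 4 h (a lower number here means a less soluble compound, a higher number a more soluble compound), compound 3 gives 9100 nM and compound 4 gives 24000 nM. In the physicochemical assay the same change gave a 2.6-fold higher number from compound 3 to compound 4 (0.42 log units; beyond the scatter), and this reading rests on a single pair: the measured solubility of compound 3, 9100 nM, and of compound 4, 24000 nM, a 2.6-fold higher number (0.42 log units; beyond the scatter).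

The compounds shown leave open how other groups on the carbonyl carbon would behave, such as a carboxylic acid, a simple methylamino or a phenylamino.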